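A few compounds are considered here, and "the series" means these few. Any claim that something is new, unique, unknown or untested is made for them only; others in the source may bear on it.

Measured in a functional assay (Nicotiana tabacum); a higher number here means a weaker inhibitor, a lower number a stronger inhibitor:
- Compound 1 `CNc1nc(SC)nc2ncccc12`: 2920 nM
- Compound 2 `CSc1nc(Nc2ccccc2)c2cccnc2n1`: 15900 nM
- Compound 3 `CSc1nc(Nc2ccc(C(C)=O)cc2)c2cccnc2n1`: not yet measured

Compound 2 stands highest of the two measured compounds, which makes it the weaker inhibitor of the pair. For the measured compounds named here, the only measured step is a 5.4-fold higher number from compound 1 to compound 2 (0.74 log units; beyond the scatter), with phenyl in place of methyl on a nitrogen on an aromatic ring.

Compound 3 keeps everything in compound 2 except for one change: acetyl in place of hydrogen on an aromatic carbon, para to a large group (acetyl in place of hydrogen on an aromatic carbon). Going by the values given here, no measured compound carries anything on that phenyl ring, and the one measured step involved a different change. It therefore gives no direction for this one. Its size, a 5.4-fold higher number from compound 1 to compound 2 (0.74 log units; beyond the scatter), serves only as a rough guide to how far a single change can move the number in this assay.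

With no direction to go on, the expected result is no shift beyond the scatter, though with wide uncertainty on either side. The expected step is a 1.1-fold lower number from compound 2 to compound 3 (0.03 log units; within the scatter). For compound 3 the estimated value is 15000 nM, with an expected range of 4000 nM to 55000 nM.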

Compound 3, half-maximal inhibitory concentration: 8960 nM
Compound 3: the middle estimate sits 1.7-fold (0.22 log units) above what was measured; the measured number falls inside the stated range.
By their numbers in this assay, from the lowest: compound 1; then compounds 3 and 2 (each within the scatter of the next).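

In this assay, compound 3 is the first compound shown with anything attached to the phenyl ring, so this result opens a part of the molecule that the earlier pair did not probe. Acetyl in place of hydrogen gives a 1.8-fold lower number from compound 2 to compound 3 (0.25 log units; within the scatter) and stays within the scatter of repeated measurements, so the two compounds cannot be told apart in this assay. At this place, on an aromatic carbon para to a large group, a group of 3 heavy atoms can therefore be added to the ring without a change the assay can resolve, and nothing in the data gives a reason for this result.

This single pair cannot show whether the same holds for every group at this place, since an amine, a carboxylic acid, a chloro group or a longer chain could give a quite different number. It also leaves open whether acetyl elsewhere on the phenyl ring would behave as it does here, and whether the same addition would read the same on a different part of the shared core.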